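The source may hold more compounds than are shown below. What is called first, only, known or untested is meant among the compounds shown, and "the series" means these compounds.

In a toxicity assay on cells (Cricetulus griseus) for cytotoxicity, read by MTT assay, with a stated time of 72 h (on this read-out higher numbers stand for weaker inhibition and lower numbers for stronger inhibition), compound 1 `Cc1c(C)c2c(c(C)c1O)CCC(C)(C(=O)NC1CC(C)(C)N([O])C1(C)C)O2` gives 194000 nM and compound 2 `Cc1c(C)c2c(c(C)c1OC(=O)CCC(=O)NC1CC(C)(C)N([O])C1(C)C)CCC(C)(C(=O)NC1CC(C)(C)N([O])C1(C)C)O2` gives 166000 nM. Among the compounds with values here, these two values lie within the scatter of each other, so compound 2 stands level with compound 1 on the only numbers available. Compound 3 `Cc1c(C)c2c(c(C)c1OC(=O)CCC(=O)O)CCC(C)(C(=O)NC1CC(C)(C)N([O])C1(C)C)O2` has not yet been measured. It differs from compound 2 by a single change on a carbonyl carbon: one oxygen atom in place of a group of 11 heavy atoms (8 carbon, 2 nitrogen, 1 oxygen; one five-membered non-aromatic ring with 1 hetero atom), on a carbonyl carbon. The hydroxy that enters sits on a carbonyl carbon whose other neighbour is a saturated chain carbon. Within the data shown here, no measured pair shows this change directly, so the expectation rests only on how close compound 1 at 194000 nM and compound 2 at 166000 nM lie. In this assay, no shift beyond the scatter is expected in either direction, and the estimated step is a 1.1-fold higher number from compound 2 to compound 3 (0.04 log units; within the scatter). For compound 3 the estimated value is 180000 nM, with an expected range from 90000 nM to 360000 nM.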

Compound 3, half-maximal inhibitory concentration: > 300000 nM
Compound 3: no number, only a limit; the forecaster's own chance of this, stated with the estimate: 10%; at least 1.6-fold (0.22 log units) between middle value and limit.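

In this assay the reading of compound 3 is a limit of the assay and not a number: the limit of > 300000 nM in this assay, at which 1 of the 3 values shown sits. Hydroxy in place of the group of 11 heavy atoms on a carbonyl carbon gives an at least 1.8-fold higher number from compound 2 to compound 3 (0.25 log units; that floor lies within the scatter), while (2-carboxyethyl)carbonyl in place of hydrogen on an oxygen on an aromatic ring gives an at least 1.5-fold higher number from compound 1 to compound 3 (0.18 log units; that floor lies within the scatter). Within the data shown here, neither floor passes the scatter, so these steps show only that neither change brings a lower number, and how far the true value of compound 3 lies past the limit stays unread.

On these data alone, it remains open whether an amine on this carbonyl carbon would give a number inside the range of the assay. The same question stands for a longer chain in place of the saturated chain carbon.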